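The source may hold more compounds than are shown below. What is called first, only, known or untested is meant among the compounds shown, and "the series" means these compounds.

Compound 1 `Cc1cc2cc(NS(=O)(=O)Cc3ccc(C(=O)NO)cc3)ccc2n(C)c1=O`: 89%
Compound 2 `Cc1cc2ccc(NS(=O)(=O)Cc3ccc(C(=O)NOCc4ccc(O)cc4)cc3)cc2n(C)c1=O`: 91%

Both numbers come from a functional assay on THP-1 cells (Homo sapiens) for antiproliferative activity, tested at 100 uM; on this read-out higher numbers stand for a stronger effect at the one concentration tested and lower numbers for a weaker effect. Among the two, compound 2 sits at one end, with compound 1 close by; the gap between them lies within the scatter, so neither can be called the stronger. Compound 3 `CC(=O)Oc1ccc(CONC(=O)c2ccc(CS(=O)(=O)Nc3ccc4cc(C)c(=O)n(C)c4c3)cc2)cc1` has not yet been measured. It differs from compound 2 by acetyl in place of hydrogen on an oxygen on an aromatic ring. Among the measured compounds shown here, no measured pair shows what this change does, so the step from compound 2 to compound 3 is expected to be small, in no set direction, as a number 3 percentage points lower from compound 2 to compound 3 (within the scatter) reflects. Compound 3 is therefore expected to give about 88%, within 70% to 98%.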

Compound 3, a percentage reported as inhibition, at one concentration (the size of the read-out at that concentration, not a potency): 91%
Estimate against measurement, compound 3: 3 percentage points below; the measured number falls inside the stated range.
By their numbers in this assay, from the lowest: compounds 1, 2 and 3 (each within the scatter of the next).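

Putting acetyl in place of hydrogen on an oxygen on an aromatic ring, which turns hydroxy into acetoxy, gives no change at the digits printed from compound 2 to compound 3 (within the scatter) in this assay. Among the compounds shown here, this is the first measured change at this position, and it shows that the oxygen can carry acetyl without a visible shift in the read-out at the one concentration tested. As far as these compounds go, whether a longer chain such as hexanoyl, or an amine or a carboxylic acid in place of the hydroxy, would leave the number unchanged remains open. Nothing available explains why this change leaves the read-out where it is.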